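The source may hold more compounds than are shown below. What is called first, only, known or untested is meant among the compounds shown, and "the series" means these compounds.

Working notes on the series. Compound 1 `O=C(NO)c1ccc(NCc2nc(-c3ccc(Br)o3)nn2-c2ccccc2)cc1` gives 55.8% in an assay on Sf9 cells for inhibition of protein deacetylase HDAC6 (Homo sapiens), read by fluorescence, with a stated time of 40 min, tested at 100 nM; a higher number here means more inhibition at the concentration tested (going by the name of the read-out), a lower number less inhibition. Compound 2 `Cc1ccc(-n2nc(-c3ccccc3)nc2CNc2ccc(C(=O)NO)cc2)cc1` gives 60.7% in this assay, a number within the scatter of compound 1. Compound 3 `Nc1ccccc1NC(=O)c1ccc(NCc2nc(-c3ccccc3)nn2-c2ccccc2)cc1` gives 5% in this assay, and the gap from compound 1 to compound 3 lies beyond the scatter. Compound 1 therefore stands second highest of the three numbers, with compound 2 nearest and compound 3 furthest below it. Compound 4 `Cc1ccc(-c2nc(CNc3ccc(C(=O)NO)cc3)n(-c3ccccc3)n2)o1` has not yet been measured in this assay. It differs from compound 1 by methyl in place of bromo on an aromatic carbon. For the measured compounds named here, no step between measured compounds covers this change, so the expectation rests on the size of the group exchanged: one heavy atom leaves and one enters, no ring, no donor or acceptor, no charge. Compound 1 and compound 2 differ in more than one place yet sit within the scatter of each other, which gives no reason to expect a large move here. The step from compound 1 to compound 4 is expected to be a number 0.8 percentage points lower from compound 1 to compound 4 (within the scatter), that is, no direction beyond the scatter. Compound 4 is estimated at 55%, within a range of 40% to 68%.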

Compound 4, a percentage reported as inhibition, at one concentration (the size of the read-out at that concentration, not a potency): 60.7%
Estimate against measurement, compound 4: 5.7 percentage points below; the range from low to high includes it.
By their numbers in this assay, from the lowest: compound 3; then compounds 1, 2 and 4 (each within the scatter of the next).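

For the compounds shown here, the exchange of 5-bromofuran-2-yl for 5-methylfuran-2-yl gives a number 4.9 percentage points higher from compound 1 to compound 4 (within the scatter) in this assay and is the first step that changes one place only. Going by these compounds alone, at this aromatic carbon next to the ring oxygen, a methyl and a bromo therefore give numbers that cannot be told apart, which the earlier compounds, differing in more than one place, could not show. No measured property bears on this result.

The compounds shown leave open whether an amine, a carboxylic acid or a longer chain on this same carbon would keep the number in this assay within the scatter of these two compounds. They also leave open whether the bromo to methyl exchange reads the same at other concentrations, as a single concentration gives no potency.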